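This account rests on a few compounds, and the source may have more. Where it says the series, first, only, none or still open, it means among the compounds named here.

For the measured compounds named here, compound 2 `CN(Cc1ccc(B(O)O)cn1)c1ccc(C(=O)Nc2ccc(F)cc2)cn1` gives 1700 nM in a functional assay on RBL cells for antagonist activity at C-X-C chemokine receptor type 1 (Homo sapiens), read by fluorescence and calcium flux, with a stated time of 30 min (on this read-out lower numbers stand for stronger inhibition and higher numbers for weaker inhibition), the highest of the two numbers measured so far; compound 1 `CN(Cc1ccc(B(O)O)cc1)c1ccc(C(=O)Nc2ccc(F)cc2)cn1` gives 1400 nM, and the step of a 1.2-fold higher number from compound 1 to compound 2 (0.08 log units; within the scatter) lies within the scatter, so the two cannot be ranked. Compound 3 `O=C(Nc1ccc(F)cc1)c1ccc(N(Cc2ccccn2)Cc2ccc(B(O)O)cn2)nc1` differs from compound 2 by pyridin-2-yl in place of hydrogen on a saturated chain carbon bound to a nitrogen on an aromatic ring, which read one bond further out is methyl to (pyridin-2-yl)methyl. Going by the values given here, no measured step covers this change; the one step available swaps rings at the same place but leaves the methyl untouched, so it offers no direct guide. With nothing pointing either way, the expected step of a 1.1-fold lower number from compound 2 to compound 3 (0.05 log units; within the scatter) is one that does not go beyond the scatter. The estimate for compound 3 in this assay is 1500 nM, with a range from 500 nM to 5000 nM.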

Compound 3, half-maximal inhibitory concentration: > 5000 nM
Compound 3 was reported as a limit; the forecaster's own chance of this, stated with the estimate: 5%; middle value at least 3.3-fold (0.52 log units) from the limit.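

Putting pyridin-2-yl in place of hydrogen on a saturated chain carbon bound to a nitrogen on an aromatic ring gives an at least 2.9-fold higher number from compound 2 to compound 3 (0.46 log units; beyond the scatter) in this assay. The earlier step, a 1.2-fold higher number from compound 1 to compound 2 (0.08 log units; within the scatter), changed the ring on the other side of that nitrogen and left the methyl in place, so it said nothing about this group; now the methyl turns out to be a place where a change can clearly weaken inhibition. The number for compound 3 is a limit of the assay, so the size of this step has only a lower bound: the limit of > 5000 nM in this assay, at which 1 of the 3 values shown sits.

The compounds shown hold only one replacement for the methyl, so how far the weakening depends on the added ring remains open. An ethyl group would ask whether any added carbon on this chain weakens inhibition, and a benzyl group whether the ring nitrogen of pyridin-2-yl plays a part.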